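The source may report more compounds than this note shows. Statements on the series, on what has been measured and on what is new or still open speak of the compounds shown alone.

The measured compounds:
Compound 1, `O=C1O[C@H]([C@@H](O)Cn2cc(CNS(=O)(=O)c3ccc(Cl)cc3F)nn2)C(OCc2ccccc2)=C1OCc1ccccc1`, gives 20 nM in an ADME assay on HFF cells (Homo sapiens) for cytotoxicity, read by MTT assay, with a stated time of 72 h; a higher number here means a weaker inhibitor, a lower number a stronger inhibitor.
Compound 2, `COc1ccc(-c2cn(C[C@H](O)[C@H]3OC(=O)C(OCc4ccccc4)=C3OCc3ccccc3)nn2)cc1`, gives in this assay a result of < 10 nM, which is a limit of the assay rather than a number.
Compound 3, `O=C1O/C(=C\Cn2cc(-c3cccc(O)c3)nn2)C(OCc2ccccc2)=C1OCc1ccccc1`, gives 42600 nM in this assay.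

Compound 2 therefore stands at the floor of what this assay can report; its result is one of the values that sit at the limit of < 10 nM in this assay, at which 1 of the 3 values shown sits, and no exact number is known for it. The results of compound 1 and compound 3 lie far apart from each other, while compound 2 cannot be ordered against either beyond its limit.

The next compound, compound 4, `CCCCCc1ccc(-c2cn(C[C@H](O)[C@H]3OC(=O)C(OCc4ccccc4)=C3OCc3ccccc3)nn2)cc1`, differs from compound 2 in one place: pentyl in place of methoxy on an aromatic carbon. The size of the step from compound 2 is uncertain. No step beyond the usual scatter is expected, so the estimated step is a number no lower from compound 2 to compound 4 (the limit leaves the size open). Compound 4 is expected to give about 10 nM in this assay, most likely between 3 nM and 40 nM.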

Compound 4, half-maximal inhibitory concentration: > 100000 nM
Compound 4 gave a limit, no number; the forecaster's own chance of this, stated with the estimate: 50%; at least 10000-fold (4.00 log units) between middle value and limit.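

Pentyl in place of methoxy on an aromatic carbon, para to a large group, gives an at least 10000-fold higher number from compound 2 to compound 4 (4.00 log units; beyond the scatter) in this assay. Going by these compounds alone, no earlier pair differed in one place, and this pair shows that a single group at this position can decide whether a compound sits at the low or the high end of what the assay reports. Each end of the step is a limit of the assay and not a number, so its full size stays unknown: the limit of > 100000 nM in this assay, at which 1 of the 4 values shown sits.

As far as these compounds go, whether the chain length or the missing oxygen drives the change stays open, and a shorter chain such as ethyl, or an amine at the same place, would help to separate the two. Also open, from the compounds shown here alone, is whether the same change has a similar effect on the core of compound 3.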